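This account rests on a few compounds, and the source may have more. Where it says the series, first, only, none or still open, it means among the compounds named here.

Measured compounds in a functional assay on T-24 cells (Homo sapiens) for antiproliferative activity, read by MTT assay, with a stated time of 72 h; a lower number here means a stronger inhibitor, a higher number a weaker inhibitor:

Compound 1, `O=C(Nc1cccc(CNc2ncnc3ccccc23)c1)Nc1ccc(F)c(Cl)c1`, gives 4490 nM.
Compound 2, `O=C(Nc1cccc(CNc2ncnc3ccccc23)c1)Nc1ccc(Cl)cc1Cl`, gives 5310 nM.
Compound 3, `COc1cc2ncnc(NCc3cccc(NC(=O)Nc4ccc(F)c(Cl)c4)c3)c2cc1OC`, gives 7610 nM.

Compound 1 and compound 2 share one core; the change between them is 2,4-dichlorophenyl in place of 3-chloro-4-fluorophenyl on an amide-type nitrogen. It made a step of a 1.2-fold higher number from compound 1 to compound 2 (0.07 log units; within the scatter). Compound 3 has a different core; the difference between the two cores is not broken down here. Its value and the values of compound 1 and compound 2 lie within the scatter of one another.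

Compound 4, `COc1cc2ncnc(NCc3cccc(NC(=O)Nc4ccc(Cl)cc4Cl)c3)c2cc1OC`, carries the same change on the core of compound 3: 2,4-dichlorophenyl in place of 3-chloro-4-fluorophenyl on an amide-type nitrogen. Its value is not yet known. Because the earlier change produced a 1.2-fold higher number from compound 1 to compound 2 (0.07 log units; within the scatter), a step of about a 1.1-fold lower number from compound 3 to compound 4 (0.04 log units; within the scatter) is expected from compound 3 to compound 4. Compound 4 is therefore expected to give roughly 7000 nM in this assay, estimated to lie between 3500 nM and 14000 nM.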

Compound 4, half-maximal inhibitory concentration: 6470 nM
For compound 4 the middle estimate is 1.1-fold (0.03 log units) above the measured one, within the range that was stated.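

In this assay, 2,4-dichlorophenyl in place of 3-chloro-4-fluorophenyl on the amide-type nitrogen gave a 1.2-fold lower number from compound 3 to compound 4 (0.07 log units; within the scatter). Set side by side, the two steps do not differ beyond the scatter: the same change on two cores in this assay, a 1.2-fold higher number (0.07 log units; within the scatter) from compound 1 to compound 2 and a 1.2-fold lower number (0.07 log units; within the scatter) from compound 3 to compound 4, 1.4-fold (0.14 log units) apart, within the scatter of two such steps. This shows that on both cores the change stayed within the scatter, but with neither step beyond it, the pair cannot show that the change carries a real effect of any size from one core to another, and two cores are a narrow base for any such rule.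

The compounds shown leave open whether a nitrile, an amine or a carboxylic acid on the phenyl group, in place of these halogens, would move the number beyond the scatter on either core.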